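Urea series: trimming one chloro from the aryl ring

The source may report more compounds than this note shows. Statements on the series, on what has been measured and on what is new or still open speak of the compounds shown alone.

Of the compounds shown here, three on the shared core have been measured. Compound 1 `COc1cc(Cl)cc(-c2nn(-c3cccc(NC(=O)c4ccc(Cl)c(Cl)c4)c3)cc2-c2ccncc2)c1` carries an amide; in a functional assay on ACHN cells (Homo sapiens) for inhibition, read by sulforhodamine B assay, with a stated time of 48 h, tested at 10 uM (on this read-out higher numbers stand for a weaker effect at the one concentration tested and lower numbers for a stronger effect), compound 1 gives 63.9%. Compound 2 `COc1cc(Cl)cc(-c2nn(-c3cccc(NC(=O)Nc4ccc(Cl)c(C(F)(F)F)c4)c3)cc2-c2ccncc2)c1` is a urea; in this assay compound 2 gives 8.78%. Compound 3 `COc1cc(Cl)cc(-c2nn(-c3cccc(NC(=O)Nc4ccc(Cl)c(Cl)c4)c3)cc2-c2ccncc2)c1` is the urea with the 3,4-dichlorophenyl group; in this assay compound 3 gives 9.65%. Among the three numbers compound 3 stands second highest: the gap to compound 2, a number 0.9 percentage points higher from compound 2 to compound 3 (within the scatter), is within the scatter, while the gap to compound 1, a number 54.3 percentage points lower from compound 1 to compound 3 (beyond the scatter), is beyond it. The parallel step a number 55.1 percentage points lower from compound 1 to compound 2 (beyond the scatter) is of the same size.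

Among the measured compounds shown here, compound 4 `COc1cc(Cl)cc(-c2nn(-c3cccc(NC(=O)Nc4cccc(C(F)(F)F)c4)c3)cc2-c2ccncc2)c1` is not yet measured. 3-(trifluoromethyl)phenyl in place of 3,4-dichlorophenyl on an amide-type nitrogen The only measured step on this ring is a number 0.9 percentage points higher from compound 2 to compound 3 (within the scatter), an exchange of one group for another that left the number unchanged within the scatter; no measured step removes a chloro from this ring. Compound 4 is therefore expected to stay close to compound 3, with the step of a number 8.4 percentage points higher from compound 3 to compound 4 (within the scatter) expected to be small. For compound 4 in this assay the estimate is 18%, in a range of 6% to 45%.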

Compound 4, a percentage reported as activity, at one concentration (the size of the read-out at that concentration, not a potency): 5.44%
Beside the measured number, compound 4's estimate is 12.6 percentage points above it, and the stated range ends above it.
By their numbers in this assay, from the lowest: compounds 4, 2 and 3 (each within the scatter of the next); then compound 1.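

In this assay, the step on the amide-type nitrogen is a number 4.2 percentage points lower from compound 3 to compound 4 (within the scatter), and the removal of the chloro from the aromatic ring of compound 2 is a number 3.3 percentage points lower from compound 2 to compound 4 (within the scatter), so this ring has now lost a chloro with no change beyond the scatter, whichever of the two ureas is the starting point. The urea compound 4 also stands well apart from the amide, with a number 58.5 percentage points lower from compound 1 to compound 4 (beyond the scatter), so the large gap seen from compound 1 to the two earlier ureas is found again with a third aryl group. Nothing available gives a reason for either observation.

The three ureas sit so close at a single concentration that none can be said to have a stronger or weaker effect at that concentration than another. As far as these compounds go, whether an unsubstituted phenyl, or a ring bearing a carboxylic acid or a morpholine, would hold the number this low remains open.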